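Compound 3 to compound 4: furan-2-yl for 2-hydroxyphenyl

The compounds below may be only part of what the source reports. "The series", "measured", "known", "first", "only" and "open" are said of these compounds alone.

In a functional assay on SW 1116 cells (Homo sapiens) for cytotoxicity, read by MTT assay, with a stated time of 48 h (a lower number here means a stronger inhibitor, a higher number a weaker inhibitor), compound 1 `O=C(CSc1nnc(-c2ccncc2)o1)N/N=C/c1ccccc1` gives 16700 nM, compound 2 `COc1ccc(/C=N/NC(=O)CSc2nnc(-c3ccncc3)o2)cc1` gives 20300 nM, and compound 3 `O=C(CSc1nnc(-c2ccncc2)o1)N/N=C/c1ccccc1O` gives 7380 nM, the lowest number of the three. Compound 4 `O=C(CSc1nnc(-c2ccncc2)o1)N/N=C/c1ccco1` is still unmeasured. The change from compound 3 is furan-2-yl in place of 2-hydroxyphenyl on a carbon with a double bond to nitrogen.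

For the measured compounds named here, three measured steps bear on this. Gaining a hydroxy group gives a 2.3-fold lower number from compound 1 to compound 3 (0.35 log units; beyond the scatter), and 2-hydroxyphenyl in place of 4-methoxyphenyl gives a 2.8-fold lower number from compound 2 to compound 3 (0.44 log units; beyond the scatter). Methoxy in place of hydrogen gives only a 1.2-fold higher number from compound 1 to compound 2 (0.08 log units; within the scatter). Going by the values given here, no compound with furan-2-yl has been measured, so any read-across is loose. Compound 4 has no hydroxy group, like compound 1, so the step seen between those two hydroxy-free and hydroxy-bearing neighbours is expected to reverse at a similar modest size. The expected change is estimated as a 2.0-fold higher number from compound 3 to compound 4 (0.31 log units; beyond the scatter). For compound 4 the estimated value is 15000 nM, with an expected range of 6500 nM to 32000 nM.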

Compound 4, half-maximal inhibitory concentration: 18800 nM
For compound 4 the middle estimate is 1.3-fold (0.10 log units) below the measured one; measured number inside the range.
By their numbers in this assay, from the lowest: compound 3; then compounds 1, 4 and 2 (each within the scatter of the next).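

In this assay, furan-2-yl in place of 2-hydroxyphenyl on the carbon with a double bond to nitrogen reverses the gain seen with the hydroxy group (a 2.5-fold higher number from compound 3 to compound 4 (0.41 log units; beyond the scatter)). Furan-2-yl in place of phenyl (a 1.1-fold higher number from compound 1 to compound 4 (0.05 log units; within the scatter)) and in place of 4-methoxyphenyl (a 1.1-fold lower number from compound 2 to compound 4 (0.03 log units; within the scatter)) both stay within the scatter, so at this position the five-membered aromatic ring with 1 hetero atom cannot be told apart from these two hydroxy-free six-membered rings, and of the four compounds only compound 3 stands apart. Nothing on hand explains why the 2-hydroxyphenyl group stands apart.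

Still open, as far as these compounds go, is whether an amine or a carboxylic acid on the phenyl ring would match the step seen with hydroxy. Also open, from the compounds shown here alone, is whether a hydroxy group on the furan-2-yl ring would bring back that step.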